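The source may report more compounds than this note shows. Statements on the series, on what has been measured and on what is new or still open speak of the compounds shown alone.

The compounds here share the core of compound 1 `Cn1c(N)c(-c2nc3ccccc3[nH]2)c2nc(C#N)c(C#N)nc21` and differ in the chain bound to an aromatic nitrogen. They were tested in a functional assay on cells (Homo sapiens) for antiproliferative activity, read by MTT assay, with a stated time of 48 h; on this read-out lower numbers stand for stronger inhibition and higher numbers for weaker inhibition. Compound 1 reads > 50000 nM, which is a limit and not a number. Compound 2 `CN(C)CCn1c(N)c(-c2nc3ccccc3[nH]2)c2nc(C#N)c(C#N)nc21`, with a 2-(dimethylamino)ethyl chain, gives 43500 nM. Compound 3 `CN1CCN(CCn2c(N)c(-c3nc4ccccc4[nH]3)c3nc(C#N)c(C#N)nc32)CC1`, whose chain ends in 4-methylpiperazin-1-yl, gives 9110 nM. Compound 2 therefore holds the higher of the two exact numbers. The gap between them is a 4.8-fold lower number from compound 2 to compound 3 (0.68 log units; beyond the scatter).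

Compound 4 `CN(C)CCCn1c(N)c(-c2nc3ccccc3[nH]2)c2nc(C#N)c(C#N)nc21` lengthens the chain: (dimethylamino)methyl in place of dimethylamino on a saturated chain carbon, two bonds along the chain from an aromatic nitrogen. In words, (dimethylamino)methyl takes the place of dimethylamino on a saturated chain carbon, two bonds along the chain from an aromatic nitrogen, so 2-(dimethylamino)ethyl becomes 3-(dimethylamino)propyl. Among the compounds with values here, no measured step changes the chain length alone. The closest guide is an at least 1.1-fold lower number from compound 1 to compound 2 (0.06 log units; that floor lies within the scatter), and its floor stays within the scatter. The gap quoted above came from swapping the end group, so it bears only loosely on this change. Compound 2 at 43500 nM already carries the dimethylamino end that compound 4 keeps, so no step beyond the scatter is expected in this assay. The estimated change is a 1.5-fold lower number from compound 2 to compound 4 (0.16 log units; within the scatter). For compound 4 the expected value is 30000 nM, with an estimated range from 11000 nM to 60000 nM.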

Compound 4, half-maximal inhibitory concentration: 1820 nM
The estimate for compound 4 lay 16-fold (1.22 log units) above the measured number; the whole stated range lies above it.
By their numbers in this assay, from the lowest: compound 4; then compound 3; then compound 2. At a limit, above all of these: compound 1.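

In this assay, within the data shown here, lengthening 2-(dimethylamino)ethyl to 3-(dimethylamino)propyl gives a 24-fold lower number from compound 2 to compound 4 (1.38 log units; beyond the scatter), which shows that chain length at this position can shift the number by a large step even when the dimethylamino end stays the same; the earlier compounds showed only a change of end group. The longer chain with the dimethylamino end also outdoes the shorter chain ending in 4-methylpiperazin-1-yl, with a 5.0-fold lower number from compound 3 to compound 4 (0.70 log units; beyond the scatter), so the advantage that the ring end held over the dimethylamino end on the shorter chain does not carry over to this comparison, where chain and end group both differ. Replacing the methyl on the shared core with the longer chain gives an at least 27-fold lower number from compound 1 to compound 4 (1.43 log units; beyond the scatter), and this is only a floor because compound 1 reads as a limit and not a number: the limit of > 50000 nM in this assay, at which 1 of the 4 values shown sits.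

On these data alone, it remains open whether a still longer chain, such as 4-(dimethylamino)butyl, would lower the number further, or whether the same lengthening would help the ring end, as in 3-(4-methylpiperazin-1-yl)propyl. The numbers also do not tell why this lengthening has so large an effect.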